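This account rests on a few compounds, and the source may have more. Where it says the series, first, only, none or still open, it means among the compounds named here.

Measured so far in an ADME assay on HeLa cells (Homo sapiens) for cytotoxicity, read by MTT assay, with a stated time of 72 h; a lower number here means that less compound is tolerated, a higher number that more compound is tolerated:

Compound 1, `Oc1ccccc1/C=N/c1sc2c(c1-c1nc3ccccc3s1)CCC2`: 168 ug/mL
Compound 2, `Clc1ccc(/C=N/c2sc3c(c2-c2nc4ccccc4s2)CCCC3)c(Cl)c1`: 542 ug/mL

Compound 2 holds the highest of the two numbers in this assay. Its nearest neighbour is compound 1, whose value stands lower by a margin that lies beyond the usual scatter, so the two are told apart with some confidence. Among the measured compounds shown here, no single-point step between the two measured compounds is available, and the account therefore says of them only what their two values show.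

The next compound, compound 3, `O=[N+]([O-])c1ccccc1/C=N/c1sc2c(c1-c1nc3ccccc3s1)CCCC2`, is drawn from compound 2 by one change: 2-nitrophenyl in place of 2,4-dichlorophenyl on a carbon with a double bond to nitrogen. For the measured compounds named here, nothing measured so far shows how such a swap moves this assay, so the expectation rests on compound 2 alone. The step is expected to be modest and, if anything, downward, toward a somewhat lower tolerated amount, as a 1.5-fold lower number from compound 2 to compound 3 (0.19 log units; within the scatter) expresses. Compound 3 is accordingly estimated at 350 ug/mL, with a range from 150 ug/mL to 800 ug/mL.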

Compound 3, half-maximal cytotoxic concentration: 369 ug/mL
Beside the measured number, compound 3's estimate is 1.1-fold (0.02 log units) below it, within the range that was stated.
By their numbers in this assay, from the lowest: compound 1; then compounds 3 and 2 (each within the scatter of the next).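

In this assay, among the compounds shown here, the exchange of 2,4-dichlorophenyl for 2-nitrophenyl on a carbon with a double bond to nitrogen supplies the first step that can be read at a single place (a 1.5-fold lower number from compound 2 to compound 3 (0.17 log units; within the scatter)), and this step stays within the scatter. At this place, then, the two aromatic groups cannot be told apart in this assay, although the group that enters carries 2 hydrogen-bond acceptors and the group that leaves carries 0. Nothing measured here offers a reason for this result or ties it to a property of either group.

Compound 1 differs from compound 2 and from compound 3 in more than one place, so the effect of its aromatic group and that of its core remain unseparated. Also open, on these data alone, is whether the same place would stay within the scatter with a phenyl ring carrying an amine or a carboxylic acid, or with a phenyl ring carrying a single chlorine.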